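Replacing the ureido group of compound 2

This account rests on a few compounds, and the source may have more. Where it says the series, first, only, none or still open, it means among the compounds named here.

In a functional assay on G-361 cells (Homo sapiens) for cytotoxicity, read by MTT assay, with a stated time of 3 days (a higher number here means a weaker inhibitor, a lower number a stronger inhibitor), compound 1 `CNc1nc(SCc2nc3ccccc3[nH]2)nc(-c2ccccc2)c1C#N` gives 12.5 nM and compound 2 `N#Cc1c(NC(N)=O)nc(SCc2nc3ccccc3[nH]2)nc1-c1ccccc1` gives 2.55 nM as the lower of the two numbers. Compound 3 `CN1CCN(c2nc(SCc3nc4ccccc4[nH]3)nc(-c3ccccc3)c2C#N)CC1` has 4-methylpiperazin-1-yl in place of ureido on an aromatic carbon. Going by the values given here, the one measured step at this place is a 4.9-fold lower number from compound 1 to compound 2 (0.69 log units; beyond the scatter) and, with no ring there in any measured compound, a similarly modest move towards a higher number is expected for compound 3 in this assay with wide uncertainty. The expected step is a 4.7-fold higher number from compound 2 to compound 3 (0.67 log units; beyond the scatter) in size. Compound 3 is estimated to lie between 2.5 nM and 60 nM around 12 nM as its middle value.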

Compound 3, half-maximal inhibitory concentration: 14.7 nM
The estimate for compound 3 lay 1.2-fold (0.09 log units) below the measured number; the measured number falls inside the stated range.
By their numbers in this assay, from the lowest: compound 2; then compounds 1 and 3 (each within the scatter of the next).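

In this assay, 4-methylpiperazin-1-yl gives up what ureido had gained at this aromatic carbon: a 5.8-fold higher number from compound 2 to compound 3 (0.76 log units; beyond the scatter). Set against methylamino, the same group shows a 1.2-fold higher number from compound 1 to compound 3 (0.07 log units; within the scatter), so a six-membered non-aromatic ring is accommodated here with no separation from the small amine. Among these three compounds, only the ureido group of compound 2 stands apart. From the compounds shown here alone, whether an acetylamino group or a morpholine ring would stand with ureido or with the other two remains open. No available evidence accounts for the separation of ureido from the other two groups.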